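Pentafluoroethyl in Place of a Sulfur Group on an Anilide

A few compounds are considered here, and "the series" means these few. Any claim that something is new, unique, unknown or untested is made for them only; others in the source may bear on it.

Three compounds of a shared core, an anilide carrying a tertiary alcohol and an aryl ether, have been tested in a functional assay on DU-145 cells (Homo sapiens) for antiproliferative activity, read by propidium iodide staining, with a stated time of 96 h; on this read-out higher numbers stand for weaker inhibition and lower numbers for stronger inhibition. Compound 1 `CC(O)(COc1cc(C(F)(F)F)cc(C(F)(F)F)c1)C(=O)Nc1cccc(S(F)(F)(F)(F)F)c1` gives 9300 nM in this assay. Compound 2 `CC(O)(COc1ccc(S(F)(F)(F)(F)F)cc1)C(=O)Nc1cc(C(F)(F)F)cc(C(F)(F)F)c1` is built from the same atoms joined differently; how the two cores differ is not broken down here. In this assay compound 2 gives 6500 nM. Compound 3 `CC(O)(COc1ccc(C(F)(F)C(F)(F)F)cc1)C(=O)Nc1cc(C(F)(F)F)cc(C(F)(F)F)c1` gives 6800 nM in this assay.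

From compound 2 to compound 3 the change is a group of 7 heavy atoms (2 carbon, 5 fluorine; no ring) in place of a group of 6 heavy atoms (5 fluorine, 1 sulfur; no ring), on an aromatic carbon. This gave a 1.0-fold higher number from compound 2 to compound 3 (0.02 log units; within the scatter). Compound 1 sits within the scatter of both compound 2 and compound 3, so none of the three can be ranked against the others.

Compound 4 `CC(O)(COc1cc(C(F)(F)F)cc(C(F)(F)F)c1)C(=O)Nc1cccc(C(F)(F)C(F)(F)F)c1` has not yet been measured. It arises from compound 1 by a group of 7 heavy atoms (2 carbon, 5 fluorine; no ring) in place of a group of 6 heavy atoms (5 fluorine, 1 sulfur; no ring), on an aromatic carbon. Going by the values given here, this is the same kind of change as the one from compound 2 to compound 3, but the place differs: in compound 3 the entering group sits para to a large group, whereas in compound 4 it sits meta to a large group.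

Because the earlier change gave a 1.0-fold higher number from compound 2 to compound 3 (0.02 log units; within the scatter), the step from compound 1 to compound 4 in this assay is expected to be a 1.0-fold higher number from compound 1 to compound 4 (0.01 log units; within the scatter). Compound 4 is accordingly estimated to give 9500 nM, between 4500 nM and 20000 nM, in this assay.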

Compound 4, half-maximal inhibitory concentration: 9800 nM
Estimate against measurement, compound 4: 1.0-fold (0.01 log units) below; low and high end bracket the measured number.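

In this assay, pentafluoroethyl in place of the sulfur group on the core of compound 1 gave a 1.1-fold higher number from compound 1 to compound 4 (0.02 log units; within the scatter). Set beside the same exchange on the other core, the two steps do not differ: the same change on two cores in this assay, a 1.0-fold higher number (0.02 log units; within the scatter) from compound 2 to compound 3 and a 1.1-fold higher number (0.02 log units; within the scatter) from compound 1 to compound 4, 1.0-fold (0.00 log units) apart, within the scatter of two such steps

So on these two cores the exchange can be carried across with no step that stands out from the scatter, even though the entering group stands meta to a large group in compound 4 and at another place in compound 3, but this rests on only two pairs, both of which gave steps within the scatter, and it does not show that the two groups would be interchangeable on a further core, at a further place or in another assay.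

The compounds shown leave open whether a group of a different kind at the same place, such as an amine, a carboxylic acid or a single chlorine atom, or a longer chain such as heptafluoropropyl, would move the number beyond the scatter. They also leave open whether the tertiary alcohol of the shared core matters to the read-out, since it stays the same in all four compounds.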